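A few compounds are considered here, and "the series" means these few. Any claim that something is new, unique, unknown or untested is made for them only; others in the source may bear on it.

Three compounds share one core and were tested in an assay on CHO cells, read by calcium flux; a lower number here means a stronger inhibitor, a higher number a weaker inhibitor. Compound 1 `O=C(Nc1ccccc1)c1csc(Cc2c(Cl)cccc2Cl)n1` carries a plain phenyl on the amide. In this assay compound 1 reaches only the limit > 4000 nM. Going by the values given here, compound 2 `O=C(Nc1ccc(C(F)(F)F)cc1)c1csc(Cc2c(Cl)cccc2Cl)n1` has a trifluoromethyl in place of hydrogen on an aromatic carbon, and in this assay compound 2 gives 88 nM, the only true number among the three. That step is an at least 45-fold lower number from compound 1 to compound 2 (1.65 log units; beyond the scatter). Compound 3 `O=C(Nc1ccc(C(F)(F)F)cc1)c1csc(CCc2c(Cl)cccc2Cl)n1` has a longer link to the dichlorinated ring. In this assay compound 3 again sits at the limit > 4000 nM. Both limits fall at the limit of > 4000 nM in this assay, at which 2 of the 3 values shown sit, so the step is an at least 45-fold higher number from compound 2 to compound 3 (1.65 log units; beyond the scatter).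

Compound 4 `O=C(Nc1ccc(C(F)(F)F)cc1)c1csc(Nc2c(Cl)cccc2Cl)n1` has not been measured. It differs from compound 2 in the same region that compound 3 alters: (2,6-dichlorophenyl)amino in place of 2,6-dichlorobenzyl on an aromatic carbon. The link keeps its length but changes its atom, and gains a hydrogen-bond donor and acceptor. Among the compounds with values here, only the step of an at least 45-fold higher number from compound 2 to compound 3 (1.65 log units; beyond the scatter) bears on this region, and it shows that a change there can cost a great deal. A change of atom is not the same as a change of length, so the outcome is open, though some loss seems likely. The expected step is a 4.5-fold higher number from compound 2 to compound 4 (0.66 log units; beyond the scatter). Compound 4 is expected to give about 400 nM, within a range from 80 nM to 4000 nM, with a fair chance of only a limit.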

Compound 4, half-maximal inhibitory concentration: 48 nM
For compound 4 the middle estimate is 8.3-fold (0.92 log units) above the measured one, and the stated range ends above it.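

In this assay, (2,6-dichlorophenyl)amino in place of 2,6-dichlorobenzyl gives a 1.8-fold lower number from compound 2 to compound 4 (0.26 log units; within the scatter), so the two values cannot be told apart. Until now this region was known only through a loss, an at least 45-fold higher number from compound 2 to compound 3 (1.65 log units; beyond the scatter), and that single step could have suggested that almost any change here is costly; the new step shows that the atom joining the dichlorinated ring to the five-membered aromatic ring can change from carbon to nitrogen, with a hydrogen-bond donor and acceptor entering, and the inhibitor stays as strong within the scatter. The compounds shown hold no measurement that explains why this change is tolerated.

On these data alone, it remains open whether other links of the same length would behave like the amino link of compound 4, such as a methylamino link, an ether oxygen or a thioether sulfur. Also open, as far as these compounds go, is whether the amino link would still read the same with the dichlorinated ring swapped for a plain phenyl or with a carboxylic acid in place of the trifluoromethyl on the amide ring.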